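Replacing one ester aryl group on a shared core

A few compounds are considered here, and "the series" means these few. Any claim that something is new, unique, unknown or untested is made for them only; others in the source may bear on it.

Measured compounds:
compound 1, `CC(=O)Oc1ccccc1C(=O)O[C@H]1CO[C@H]2[C@@H]1OC[C@H]2OC(=O)c1ccccc1O`: 0.0825 h
compound 2, `CC(=O)Oc1ccccc1C(=O)O[C@H]1CO[C@H]2[C@@H]1OC[C@H]2OC(=O)c1ccnn1C`: 0.0963 h

Both compounds were tested in an ADME assay on a cell-free system (plasma, Homo sapiens) for metabolic stability, with Plasma (Rattus norvegicus) as the target, read by HPLC, at pH 7.4; on this read-out higher numbers stand for a longer-lived compound and lower numbers for a shorter-lived compound. In this assay compound 1 gives 0.0825 h, and compound 2 gives 0.0963 h. Compound 1 holds the lowest of the two numbers, and its nearest neighbour is compound 2, with a step of a 1.2-fold higher number from compound 1 to compound 2 (0.07 log units; within the scatter), a gap that stays within the scatter.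

The unmeasured compound 3, `CC(=O)Oc1ccccc1C(=O)O[C@H]1CO[C@H]2[C@@H]1OC[C@H]2OC(=O)c1cccc(C)c1`, is reached from compound 1 by one change:

3-methylphenyl in place of 2-hydroxyphenyl on a carbonyl carbon

Going by the values given here, only one measured step bears on this change. The step of a 1.2-fold higher number from compound 1 to compound 2 (0.07 log units; within the scatter) also replaces the 2-hydroxyphenyl on the carbonyl carbon of compound 1, there by 1-methyl-1H-pyrazol-5-yl, and it stayed within the scatter. Among the compounds with values here, the change to 3-methylphenyl has no direct precedent, but the single comparison available suggests that exchanging this group leaves the half-life largely untouched. Compound 3 is therefore expected to show a step of about a 1.1-fold higher number from compound 1 to compound 3 (0.04 log units; within the scatter), that is, no change beyond the scatter. The estimate for compound 3 is 0.09 h, with a range from 0.04 h to 0.2 h.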

Compound 3, half-life: 0.165 h
Compound 3: middle estimate off by 1.8-fold (0.26 log units), on the low side, within the range that was stated.
By their numbers in this assay, from the lowest: compounds 1, 2 and 3 (each within the scatter of the next).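

In this assay the exchange on this carbonyl carbon gives a step of a 2.0-fold higher number from compound 1 to compound 3 (0.30 log units; within the scatter) and, between the two replacing groups, a step of a 1.7-fold higher number from compound 2 to compound 3 (0.23 log units; within the scatter), so 2-hydroxyphenyl, 1-methyl-1H-pyrazol-5-yl and 3-methylphenyl all lie within the scatter of one another. The new comparison extends this to a replacement with a six-membered aromatic ring of carbon only: 2-hydroxyphenyl, with 1 hydrogen-bond donor and 1 hydrogen-bond acceptor, gives way to 3-methylphenyl, with 0 of each, and the half-life still shows no difference beyond the scatter. Nothing in the data at hand accounts for these numbers, so the result stands as an observation on these three compounds alone.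

The compounds shown leave open whether a phenyl ring carrying an amine or a carboxylic acid, or a longer alkyl chain in place of the methyl of 3-methylphenyl, would move the half-life beyond the scatter. They also leave open whether this position would behave the same way if the 2-acetoxyphenyl ester on the other side of the shared core were replaced by a different group.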